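From methoxymethyl to hydroxymethyl on compound 3

This account rests on a few compounds, and the source may have more. Where it says the series, first, only, none or still open, it means among the compounds named here.

Values so far in a physicochemical assay for lipophilicity, read by HPLC, at pH 7.5; a higher number here means a more lipophilic compound, a lower number a more polar compound
- compound 1 `CC[C@@H](Nc1c(C#N)c(-c2ccc(-c3cccc(Cl)c3OC)cc2)nc2cnccc12)C(N)=O` gives 3.1
- compound 2 `CC[C@@H](Nc1c(C#N)c(-c2ccc(-c3cnccc3C)cc2)nc2cnccc12)C(N)=O` gives 2
- compound 3 `CC[C@@H](Nc1c(C#N)c(-c2ccc(-c3ccccc3COC)cc2)nc2cnccc12)C(N)=O` gives 2.6

Compound 3 (2.6) stands second of these three, under compound 1 and over compound 2. Compound 4 `CC[C@@H](Nc1c(C#N)c(-c2ccc(-c3ccccc3CO)cc2)nc2cnccc12)C(N)=O` differs from it in one place: hydrogen in place of methyl on an oxygen on a saturated carbon turns 2-(methoxymethyl)phenyl into 2-(hydroxymethyl)phenyl. Among the measured compounds shown here, no measured step makes this exact change. Swapping the whole group on an aromatic carbon gave a number 0.50 log units lower from compound 1 to compound 3 (beyond the scatter) and a number 0.60 log units higher from compound 2 to compound 3 (beyond the scatter) as modest steps. Only a methyl leaves here, so a modest fall is expected (a number 0.40 log units lower from compound 3 to compound 4 (beyond the scatter)). In this assay compound 4 is estimated at 2.2 (expected range 1.8 to 2.6).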

Compound 4, distribution coefficient: 2.1
The estimate for compound 4 lay 0.10 log units above the measured number; low and high end bracket the measured number.
By their numbers in this assay, from the lowest: compounds 2 and 4 (each within the scatter of the next); then compound 3; then compound 1.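

In this assay, losing just the methyl from the oxygen of 2-(methoxymethyl)phenyl moves the number as far as swapping a whole group did (a number 0.50 log units lower from compound 3 to compound 4 (beyond the scatter)). With the hydroxymethyl group in place, the compound matches the one carrying 4-methylpyridin-3-yl (a number 0.10 log units higher from compound 2 to compound 4 (within the scatter)) but remains well apart from the one carrying 3-chloro-2-methoxyphenyl (a number 1.00 log units lower from compound 1 to compound 4 (beyond the scatter)). Nothing measured here accounts for the size of these steps. On these data alone, this change appears in a single pair, so its size on other compounds remains open. As far as these compounds go, how an amine or a longer chain in this place would read is also open.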